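The source may hold more compounds than are shown below. What is called first, only, known or untested is meant among the compounds shown, and "the series" means these compounds.

Measured so far in a physicochemical assay for lipophilicity, read by HPLC, measured as octanol-water partition; on this read-out lower numbers stand for lower lipophilicity and higher numbers for higher lipophilicity:
Compound 1 `O=C1CCC(=O)N1C[C@H]1CN(c2ccc(-n3cc(-c4ccccn4)cn3)c(F)c2)C(=O)O1` gives 1.58.
Compound 2 `O=C1O[C@@H](Cn2ccnc2)CN1c1ccc(-n2cc(-c3ccccn3)cn2)c(F)c1` gives 1.73.

Compound 1 stands lowest of the two numbers shown. For the measured compounds named here, its nearest neighbour is compound 2, and the single measured step, a number 0.15 log units higher from compound 1 to compound 2 (within the scatter), stays within the scatter, so the two compounds cannot be placed in any order.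

Compound 3 `CS(=O)(=O)NC[C@H]1CN(c2ccc(-n3cc(-c4ccccn4)cn3)c(F)c2)C(=O)O1` has not yet been measured. It differs from compound 1 in one place: methanesulfonamido in place of 2,5-dioxopyrrolidin-1-yl on a saturated chain carbon bound to a saturated ring carbon.

Going by the values given here, only one measured step bears on this change, and only in part: it removes the same leaving group at the same place but brings in a different entering group, so it gives no direct guide to compound 3. It does show that an exchange at this position left the number within the scatter in the one case seen.

On the change itself, compound 3 is expected to come out somewhat lower than compound 1, by a step of a number 0.38 log units lower from compound 1 to compound 3 (beyond the scatter) in this assay, a modest move that may or may not clear the scatter. The estimate for compound 3 is 1.2, with a range from 0.8 to 1.6.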

Compound 3, partition coefficient: 1.38
For compound 3 the middle estimate is 0.18 log units below the measured one; the measured number falls inside the stated range.
By their numbers in this assay, from the lowest: compounds 3, 1 and 2 (each within the scatter of the next, the first and the last beyond it).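

At this place, on a saturated chain carbon bound to a saturated ring carbon, this assay now gives its first step that clears the scatter, for methanesulfonamido in place of 1H-imidazol-1-yl (a number 0.35 log units lower from compound 2 to compound 3 (beyond the scatter)). Methanesulfonamido in place of 2,5-dioxopyrrolidin-1-yl, which gives up the five-membered ring for a group with no ring, stays inside the scatter (a number 0.20 log units lower from compound 1 to compound 3 (within the scatter)), so compound 1 and compound 3 cannot be put in order. For the compounds shown here, the read-out thus does respond to the group held at this carbon, although only one of the three pairs separates, and no measurement at hand explains why that pair does.

The three compounds leave open whether an amine, a carboxylic acid or a longer chain at this carbon would stand apart from them or fall within the same narrow span. They also leave open whether the step seen with methanesulfonamido would hold if the methyl on its sulfur gave way to a phenyl group, or if the same exchange were carried out on a different core.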